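A few compounds are considered here, and "the series" means these few. Any claim that something is new, unique, unknown or untested is made for them only; others in the source may bear on it.

Measured so far:
compound 1, `Cc1c(F)c(N)c2c(=O)cc(-c3ccc(N)c(F)c3)oc2c1F` — > 100000 nM
compound 2, `CCCCc1c(F)c(N)c2c(=O)cc(-c3ccc(N)c(F)c3)oc2c1F` — > 100000 nM
compound 3, `CCCOCc1c(F)c(N)c2c(=O)cc(-c3ccc(N)c(F)c3)oc2c1F` — 78000 nM

In a functional assay on HeLa cells (Homo sapiens) for cytotoxicity, read by neutral red uptake, with a stated time of 3 days (on this read-out lower numbers stand for stronger inhibition and higher numbers for weaker inhibition), compound 1 sits at a limit of the assay, > 100000 nM. In this assay compound 2 likewise sits at a limit, > 100000 nM. Compound 3 alone gives a number in this assay, 78000 nM. The change propyl in place of hydrogen on a saturated chain carbon bound to an aromatic carbon gives a step that the two limits leave unreadable from compound 1 to compound 2, left unreadable due to the limit of > 100000 nM in this assay, at which 2 of the 3 values shown sit. The two cores differ by propoxy in place of hydrogen on a saturated chain carbon bound to an aromatic carbon, and that difference gives an at least 1.2-fold lower number from compound 1 to compound 3 (0.10 log units; that floor lies within the scatter).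

Compound 4, `CCCCCCOCc1c(F)c(N)c2c(=O)cc(-c3ccc(N)c(F)c3)oc2c1F`, is not yet measured in this assay. It differs from compound 3 by propyl in place of hydrogen on a saturated chain carbon, three bonds along the chain from an oxygen on a saturated carbon. This is the same kind of change as from compound 1 to compound 2, but the place differs: there the carbon is bound to an aromatic carbon, here it lies three bonds along the chain from an oxygen on a saturated carbon. Since the earlier step could not be read, the expectation for compound 4 rests on compound 3 at 78000 nM, and a step of a 1.1-fold lower number from compound 3 to compound 4 (0.05 log units; within the scatter) is estimated. Compound 4 is therefore expected to give about 70000 nM, within 30000 nM to 120000 nM.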

Compound 4, half-maximal inhibitory concentration: > 100000 nM
Compound 4 gave a limit, no number (the forecaster's own chance of this, stated with the estimate: 35%); middle value at least 1.4-fold (0.15 log units) away from the limit.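

In this assay, propyl on the propoxy chain gives an at least 1.2-fold higher number from compound 3 to compound 4 (0.10 log units; that floor lies within the scatter), which is only a floor, so it establishes neither a real rise nor its size. As far as these compounds go, the same change on the core of compound 1 and the remaining steps cannot be read, due to one shared limit: the limit of > 100000 nM in this assay, at which 3 of the 4 values shown sit. It therefore stays open whether this change carries from one core to the other, since neither core gives it a measured size.

Within the data shown here, only compound 3 gives a number, 78000 nM, so no step here has a measured value at both ends. From the compounds shown here alone, whether an amine or a carboxylic acid in place of the propyl would give a readable number in this assay remains open.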